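The source may report more compounds than this note shows. Statements on the series, on what has been measured and on what is new or still open speak of the compounds shown alone.

Compound 3, `O=C(CCCCCCNC(=O)c1cc(-c2ccc(F)cc2)[nH]n1)NO`, carries a hydroxamic acid at the end of a saturated chain that is joined through an amide to the shared core, with a fluorophenyl group on that core. In an assay on cells for inhibition of protein deacetylase HDAC6 (Homo sapiens), read by fluorescence, with stated times of 15 min and 60 min (a higher number here means a weaker inhibitor, a lower number a stronger inhibitor), compound 3 gives 22 nM. For the measured compounds named here, this is the lowest of the three numbers measured so far, but it sits within the usual scatter of the other two. Compound 1, `Cc1ccc(-c2cc(C)nn2Cc2ccc(C(=O)NO)cc2)cc1`, gives 29 nM in this assay, and compound 2, `CCc1cc(-c2ccc(F)cc2)nn1Cc1ccc(C(=O)NO)cc1`, gives 35 nM, so no order among the three can be read from these values.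

Compound 4, `O=C(CCCCCNC(=O)c1cc(-c2ccc(F)cc2)[nH]n1)NO`, has not yet been measured in this assay. It differs from compound 3 in one place: hydroxycarbamoyl in place of (hydroxycarbamoyl)methyl on a saturated chain carbon, five bonds along the chain from an amide-type nitrogen. The chain that separates the amide from the hydroxamic acid is thus one carbon shorter, while the core and the fluorophenyl group are unchanged. Going by the values given here, no pair of measured compounds shows a change of this kind, so the direction and size of the step rest on expectation alone. The expected step from compound 3 to compound 4 is a 2.3-fold higher number from compound 3 to compound 4 (0.36 log units; beyond the scatter), a modest move toward a higher number. Compound 4 is therefore estimated to give 50 nM in this assay, with a range from 15 nM to 170 nM.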

Compound 4, half-maximal inhibitory concentration: 29 nM
Beside the measured number, compound 4's estimate is 1.7-fold (0.24 log units) above it; the range from low to high includes it.
By their numbers in this assay, from the lowest: compounds 3, 1, 4 and 2 (each within the scatter of the next).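

In this assay, the exchange of (hydroxycarbamoyl)methyl for hydroxycarbamoyl on a saturated chain carbon, five bonds along the chain from an amide-type nitrogen, gives a 1.3-fold higher number from compound 3 to compound 4 (0.12 log units; within the scatter), so the two compounds cannot be told apart by this read-out. For the compounds shown here, this is the first direct reading of any single change, as the earlier compounds offered no pair that differed in one place, and it shows that, at this position, a chain one carbon shorter leaves the number inside the scatter. The result does not extend beyond this one pair, and nothing measured here speaks to why the chain length makes no visible difference at this point.

The compounds shown leave open how far this insensitivity runs, since a single step cannot tell whether a still shorter chain or a longer chain would also stay within the scatter. They also leave open what would happen if a carboxylic acid or an amine stood in place of the hydroxycarbamoyl group on this chain, since every compound shown carries the hydroxamic acid.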